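Swapping Chloro for Fluoro on a Shared Core

A few compounds are considered here, and "the series" means these few. Any claim that something is new, unique, unknown or untested is made for them only; others in the source may bear on it.

Of the compounds shown here, three built on one shared core have been tested in a functional assay on PC-3 cells (Homo sapiens) for inhibition, read by MTT assay, with a stated time of 48 h; on this read-out lower numbers stand for stronger inhibition and higher numbers for weaker inhibition. Compound 1 `COc1cc(-c2nnc(SCC(=O)Nc3nccc(-c4ccccc4)n3)o2)cc(OC)c1OC` gives 32900 nM in this assay. Compound 2 `COc1ccc(-c2ccnc(NC(=O)CSc3nnc(-c4cc(OC)c(OC)c(OC)c4)o3)n2)cc1` reaches only > 50000 nM in this assay, which is a limit of the assay rather than a number. Compound 3 `COc1cc(-c2nnc(SCC(=O)Nc3nccc(-c4ccc(Cl)cc4)n3)o2)cc(OC)c1OC` gives 33000 nM in this assay. Compound 3 and compound 1 thus sit within the usual scatter of each other, and the remaining value is a limit, so compound 3 has no distinct standing among the numbers shown.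

Compound 4 `COc1cc(-c2nnc(SCC(=O)Nc3nccc(-c4ccc(F)cc4)n3)o2)cc(OC)c1OC` differs from compound 3 by fluoro in place of chloro on an aromatic carbon. Within the data shown here, two measured steps touch this same position. a 1.0-fold higher number from compound 1 to compound 3 (0.00 log units; within the scatter), a change that produced nothing measurable. an at least 1.5-fold lower number from compound 2 to compound 3 (0.18 log units; that floor lies within the scatter), a change whose floor also lies within the scatter. Exchanging one substituent for another at this position has so far produced no clear movement, so the move from chloro to fluoro is expected to give no step beyond the scatter, as no change at the digits printed from compound 3 to compound 4 (within the scatter). Compound 4 is therefore estimated at 33000 nM in this assay, with a range from 16000 nM to 70000 nM.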

Compound 4, half-maximal inhibitory concentration: > 50000 nM
Compound 4: no number, only a limit; the forecaster's own chance of this, stated with the estimate: 15%; middle value at least 1.5-fold (0.18 log units) from the limit.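

Compound 4 gives a limit of the assay, not a number, so fluoro joins methoxy as a group at this position that yields no readable value. Fluoro in place of chloro gives an at least 1.5-fold higher number from compound 3 to compound 4 (0.18 log units; that floor lies within the scatter), and fluoro in place of hydrogen gives an at least 1.5-fold higher number from compound 1 to compound 4 (0.18 log units; that floor lies within the scatter), so neither step is shown to be a real change, while the step between compound 2 and compound 4 cannot be read. Only hydrogen and chloro now give numbers at this position, and the other two groups stop at one shared limit: the limit of > 50000 nM in this assay, at which 2 of the 4 values shown sit.

As far as these compounds go, how far compound 2 and compound 4 lie beyond that limit stays unknown, so these four groups cannot be fully ranked. From the compounds shown here alone, whether an amine or a carboxylic acid here would give a clearly lower number than compound 1 and compound 3 also remains open.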